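The source may hold more compounds than are shown below. What is called first, only, known or untested is meant among the compounds shown, and "the series" means these compounds.

Compound 3, `CNc1nc(NCCCN(C)C)c2sc(-c3ccc(C(C)=O)cc3)cc2n1`, is one of three close relatives whose solubility has been measured in a physicochemical assay for solubility, at pH 2; on this read-out lower numbers stand for lower solubility and higher numbers for higher solubility. For compound 3 the read-out is only a limit of the assay, > 100 ug/mL. Compound 1, `CNc1nc(NCCCN(C)C)c2sc(-c3ccc(S(C)(=O)=O)cc3)cc2n1`, carries a methylsulfonyl group where compound 3 carries an acetyl, and in this assay compound 1 likewise reaches a limit, > 100 ug/mL. Compound 2, `CNc1nc(NCCCN(C)C)c2sc(-c3ccc(OC)nc3)cc2n1`, carries a 6-methoxypyridin-3-yl group where compound 3 carries a 4-acetylphenyl, and in this assay compound 2 also reaches a limit, > 100 ug/mL. Because (the limit of > 100 ug/mL in this assay, at which 3 of the 3 values shown sit), the step that the two limits leave unreadable from compound 1 to compound 3 and the step that the two limits leave unreadable from compound 2 to compound 3 cannot be read in size or direction. The new compound 4, `CNc1nc(NCCCN(C)C)c2sc(-c3ccccc3)cc2n1`, differs from compound 3 by hydrogen in place of acetyl on an aromatic carbon. Neither measured step offers a readable size for a change of this kind, so the three measured compounds give no pointer toward higher or lower solubility. The step of a number no higher from compound 3 to compound 4 (the limit leaves the size open) is therefore expected to be small or none beyond the scatter, with compound 4 most likely sitting at the same limit as its relatives. For compound 4 the estimate in this assay is 100 ug/mL, with a range from 40 ug/mL to 300 ug/mL.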

Compound 4, solubility: > 100 ug/mL
Compound 4: only a limit was reported; the forecaster's own chance of this, stated with the estimate: 65%; the middle value sits exactly at the limit.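

In this assay compound 4 gives > 100 ug/mL, which is a limit of the assay. Its steps from compound 1, compound 2 and compound 3 therefore cannot be read in size or direction: the limit of > 100 ug/mL in this assay, at which 4 of the 4 values shown sit. The compounds shown leave open whether these four differ at all in this assay, and by how much.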